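Replacing phenyl on the carbonyl of compound 3

The source may report more compounds than this note shows. Statements on the series, on what has been measured and on what is new or still open speak of the compounds shown alone.

compound 1 `Cc1cc(C)c(NC(=O)c2sccc2S(=O)(=O)Nc2onc(C)c2Cl)c(C)c1`: 81600 nM
compound 2 `Cc1cc(C)c(NC(=O)c2sccc2S(=O)(=O)Nc2onc(C)c2Cl)c(-c2ncco2)c1`: 134000 nM
compound 3 `Cc1cc(C)c(NC(=O)c2sccc2S(=O)(=O)Nc2onc(C)c2Cl)c(C(=O)c2ccccc2)c1`: 63100 nM

In an in vivo ADME assay on the whole organism (plasma) for pharmacokinetics, with Rattus norvegicus as the target, at a dose of 50 mg/kg by the oral route (a lower number here means less compound in the circulation, a higher number more compound in the circulation at the dose given), compound 3 gives 63100 nM, which lies within the scatter of compound 1 and beyond it only against compound 2. Compound 4 `Cc1cc(C)c(NC(=O)c2sccc2S(=O)(=O)Nc2onc(C)c2Cl)c(C(=O)CS(C)(=O)=O)c1` carries (methylsulfonyl)methyl in place of phenyl on a carbonyl carbon. Going by the values given here, no measured step makes this exact change. The closest evidence comes from swaps of groups on an aromatic carbon: a 1.3-fold lower number from compound 1 to compound 3 (0.11 log units; within the scatter), a 1.6-fold higher number from compound 1 to compound 2 (0.22 log units; within the scatter) and a 2.1-fold lower number from compound 2 to compound 3 (0.33 log units; beyond the scatter). Only the last clears the scatter, and modestly, so no step beyond the scatter is expected. The expected change is a 1.3-fold higher number from compound 3 to compound 4 (0.10 log units; within the scatter). Compound 4 is estimated at 80000 nM, with an expected range of 35000 nM to 180000 nM.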

Compound 4, maximal plasma concentration: 68300 nM
For compound 4 the middle estimate is 1.2-fold (0.07 log units) above the measured one, and the stated range covers the measured number.
By their numbers in this assay, from the lowest: compounds 3, 4, 1 and 2 (each within the scatter of the next, the first and the last beyond it).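

In this assay, replacing phenyl with (methylsulfonyl)methyl on the carbonyl carbon gives a 1.1-fold higher number from compound 3 to compound 4 (0.03 log units; within the scatter), so at this position an open chain with hydrogen-bond acceptors reads the same as the aromatic ring. Set against the groups on the aromatic carbon, ((methylsulfonyl)methyl)carbonyl gives a 1.2-fold lower number from compound 1 to compound 4 (0.08 log units; within the scatter) and a 2.0-fold lower number from compound 2 to compound 4 (0.29 log units; within the scatter), so compound 4 separates from none of the three earlier compounds. Nothing measured here explains this flat response. As far as these compounds go, whether an amine, a carboxylic acid or a longer chain on this carbonyl carbon would leave the number equally unchanged remains open.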